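The compounds below may be only part of what the source reports. "The series", "measured", "known", "first", "only" and "open" are said of these compounds alone.

Measured compounds:
- compound 1, `COc1cc(-c2nn(-c3cccc(NC(=O)Nc4ccc(Cl)c(Cl)c4)c3)cc2-c2ccncc2)ccc1Cl`: > 50000 nM
- compound 2, `O=C(Nc1cccc(-n2cc(-c3ccncc3)c(-c3ccc(Cl)c(O)c3)n2)c1)Nc1ccc(Cl)c(Cl)c1`: > 32500 nM
- compound 3, `O=C(Nc1cccc(-n2cc(-c3ccncc3)c(-c3ccc(Cl)c(O)c3)n2)c1)Nc1cc(C(F)(F)F)cc(C(F)(F)F)c1`: 6120 nM

In a functional assay on NCI-H226 cells (Homo sapiens) for inhibition, read by sulforhodamine B assay, with a stated time of 48 h (a higher number here means a weaker inhibitor of growth, a lower number a stronger inhibitor of growth), compound 1 gives > 50000 nM, which is a limit of the assay and not a number. Compound 2 likewise gives only a limit in this assay, > 32500 nM. Within the data shown here, compound 3 is the one compound of the three with a number, 6120 nM. Among the measured compounds shown here, the only step between neighbours that share all but one place, a step that the two limits leave unreadable from compound 1 to compound 2, cannot be read, since both ends sit at a limit: the limit of > 50000 nM in this assay, at which 1 of the 3 values shown sits, for compound 1 and the limit of > 32500 nM in this assay, at which 1 of the 3 values shown sits, for compound 2. Compound 2 and compound 3 are not a single-place pair, so their two values can only be set side by side: a limit for compound 2, a number for compound 3.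

The unmeasured compound 4, `COc1cc(-c2nn(-c3cccc(NC(=O)Nc4ccc(Cl)c(C(F)(F)F)c4)c3)cc2-c2ccncc2)ccc1Cl`, differs from compound 1 in one place: trifluoromethyl in place of chloro on an aromatic carbon. For the measured compounds named here, no measured step bears directly on this change, and the one measured step is unreadable, so there is no ground to expect a step in this assay beyond the scatter in either direction. Compound 4 is therefore expected to stay near its parent, with the step of an at least 1.6-fold lower number from compound 1 to compound 4 (0.22 log units; that floor lies within the scatter) carrying wide uncertainty. The estimate for compound 4 in this assay is 30000 nM, with a range from 8000 nM to 100000 nM.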

Compound 4, concentration for total growth inhibition: > 32500 nM
Compound 4: no number, only a limit (the forecaster's own chance of this, stated with the estimate: 50%); at least 1.0-fold (0.03 log units) between middle value and limit.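

Going from compound 1 to compound 4, trifluoromethyl in place of chloro gives no readable step in this assay, as neither compound has a number. Compound 1 sits at a limit: the limit of > 50000 nM in this assay, at which 1 of the 4 values shown sits. Compound 4 also sits at a limit: the limit of > 32500 nM in this assay, at which 2 of the 4 values shown sit. The compounds shown leave open whether this change alters growth inhibition at all.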